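This account rests on a few compounds, and the source may have more. Where it says the series, first, only, none or still open, it means among the compounds named here.

Of the compounds shown here, three built on a shared core have been tested in an ADME assay on NIH3T3 cells (Mus musculus) for cytotoxicity, read by MTT assay; a lower number here means a stronger inhibitor, a higher number a weaker inhibitor. Compound 1 `N#Cc1c(-c2ccc(O)cc2)c(C#N)c(=O)n(/N=C/c2cn(-c3ccccc3)nc2-c2ccccc2)c1N` gives 110 ug/mL in this assay. Compound 2 `Cc1ccc(-c2c(C#N)c(N)n(/N=C/c3cn(-c4ccccc4)nc3-c3ccccc3)c(=O)c2C#N)cc1` gives 98 ug/mL, and compound 3 `N#Cc1c(-c2cccc([N+](=O)[O-])c2)c(C#N)c(=O)n(/N=C/c2cn(-c3ccccc3)nc2-c2ccccc2)c1N` gives 124 ug/mL. The step of a 1.1-fold lower number from compound 1 to compound 2 (0.05 log units; within the scatter) stays within the scatter, as do the steps of a 1.1-fold higher number from compound 1 to compound 3 (0.05 log units; within the scatter) and a 1.3-fold higher number from compound 2 to compound 3 (0.10 log units; within the scatter). Compound 3 therefore has the highest number of the three as written, but every step from it to the other two lies within the scatter, so the three values cannot really be told apart.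

Compound 4 `N#Cc1c(-c2ccc(C(F)(F)F)cc2)c(C#N)c(=O)n(/N=C/c2cn(-c3ccccc3)nc2-c2ccccc2)c1N` has not yet been measured in this assay. It differs from compound 3 in one place: 4-(trifluoromethyl)phenyl in place of 3-nitrophenyl on an aromatic carbon. The measured steps that bear on this change are the exchanges of the aryl group on the same carbon, a 1.1-fold higher number from compound 1 to compound 3 (0.05 log units; within the scatter) and a 1.3-fold higher number from compound 2 to compound 3 (0.10 log units; within the scatter) among them, and each stayed within the scatter. Compound 4 is therefore expected to give about 115 ug/mL in this assay. Its expected range runs from 70 ug/mL to 190 ug/mL. The expected step of a 1.1-fold lower number from compound 3 to compound 4 (0.03 log units; within the scatter) is thus none beyond the scatter.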

Compound 4, half-maximal inhibitory concentration: > 200 ug/mL
Compound 4 ended at the assay's limit; the forecaster's own chance of this, stated with the estimate: 5%; middle value at least 1.7-fold (0.24 log units) away from the limit.
By their numbers in this assay, from the lowest: compounds 2, 1 and 3 (each within the scatter of the next). At a limit, above all of these: compound 4.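

In this assay, compound 4 is the only compound shown that ends at a limit and not at a number: the limit of > 200 ug/mL in this assay, at which 1 of the 4 values shown sits.

From the compounds shown here alone, on this carbon, opposite the ring nitrogen, 4-hydroxyphenyl, 4-methylphenyl and 3-nitrophenyl gave values within the scatter of one another, whereas the true value with 4-(trifluoromethyl)phenyl is unknown and could lie far from theirs. The three new steps are only floors: an at least 1.6-fold higher number from compound 3 to compound 4 (0.20 log units; that floor lies within the scatter), an at least 2.0-fold higher number from compound 2 to compound 4 (0.30 log units; that floor lies within the scatter) and an at least 1.8-fold higher number from compound 1 to compound 4 (0.25 log units; that floor lies within the scatter); the true steps may be larger, but as printed, none is shown to exceed the scatter.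

Going by these compounds, what remains open is how far the value of compound 4 lies past the limit. On these data alone, it is also open whether the outcome follows the trifluoromethyl group or its place on the phenyl ring, a question that 3-(trifluoromethyl)phenyl and 4-nitrophenyl groups on this carbon could help to separate.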